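This account rests on a few compounds, and the source may have more. Where it says the series, first, only, none or still open, it means among the compounds named here.

- Compound 1 `C=C(C(=O)OCC)C(O)c1ccccc1[N+](=O)[O-]`: 316 nM
- Compound 2 `C=C(C(=O)OCC)C(OCCC(=O)OCC)c1ccc(Cl)cc1Cl`: 79.4 nM
- Compound 3 `C/C=C(\C(=O)OCC)C(O)c1ccccc1Cl`: 100 nM

In a functional assay on THP-1 cells (Homo sapiens), read by colorimetric assay, with a stated time of 1 h (a higher number here means that more compound is needed for the effect, a lower number that less compound is needed), compound 1 gives 316 nM, the highest of the three numbers, so it needs the most compound for the effect. Compound 2 (79.4 nM) and compound 3 (100 nM) both lie lower, beyond the scatter.

Compound 4 `C=C(C(=O)OCC)C(O)c1ccccc1F` has not yet been measured. It keeps the core of compound 1 but has fluoro in place of nitro on an aromatic carbon.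

For the measured compounds named here, no two measured compounds differ in just one place, so the data do not show the size of this swap directly. The only hint is indirect: compound 2 (79.4 nM) and compound 3 (100 nM) have no nitro group and sit lower in this assay, although they also differ from compound 1 elsewhere. A modest fall near the edge of the scatter is therefore expected, with an estimated step of a 2.1-fold lower number from compound 1 to compound 4 (0.32 log units; beyond the scatter). For compound 4, the estimate is 150 nM, with an expected range from 50 nM to 400 nM.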

Compound 4, half-maximal effective concentration: 158 nM
For compound 4 the middle estimate is 1.1-fold (0.02 log units) below the measured one; measured number inside the range.
By their numbers in this assay, from the lowest: compounds 2, 3, 4 and 1 (each within the scatter of the next, the first and the last beyond it).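

For the compounds shown here, this is the first comparison that changes one group and nothing else: on this aromatic carbon, ortho to a group of 9 heavy atoms, fluoro takes the place of nitro. In this assay the swap gives a 2.0-fold lower number from compound 1 to compound 4 (0.30 log units; within the scatter), so the two compounds cannot be told apart, and a single fluorine atom serves here as well as the three heavy atoms of the nitro group, including its 2 hydrogen-bond acceptors. Nothing available explains why the two groups read alike.

As far as these compounds go, only these two groups can be compared directly at this position, so it remains open whether an amine or a carboxylic acid there would leave the number in the same range. From the compounds shown here alone, a longer chain at this carbon is an equally open question.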